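Methyl in place of chloro on a Mer kinase inhibitor

The source may hold more compounds than are shown below. What is called first, only, known or untested is meant among the compounds shown, and "the series" means these compounds.

Measured compounds:
compound 1 `CN(Cc1ccc2nccn2c1)c1nnc(-c2ccc(C3CC3)cc2)o1` — 794 nM
compound 2 `CN(Cc1ccc2nccn2c1)c1nnc(-c2ccc(-c3ccccc3C#N)cc2)o1` — 25.1 nM
compound 3 `Cc1nn(C)c(C)c1-c1ccc(-c2nnc(N(C)Cc3ccc4nccn4c3)o2)c(Cl)c1` — 2.51 nM

In an assay on isolated protein for inhibition of tyrosine-protein kinase Mer (Homo sapiens), read by LC-MS (a lower number here means a stronger inhibitor, a higher number a weaker inhibitor), compound 3 gives the lowest number of the three, lower than compound 2 and far lower than compound 1, both gaps beyond the scatter. Compound 4 `Cc1cc(-c2c(C)nn(C)c2C)ccc1-c1nnc(N(C)Cc2ccc3nccn3c2)o1` differs from compound 3 by methyl in place of chloro on an aromatic carbon. Within the data shown here, the only measured step, a 32-fold lower number from compound 1 to compound 2 (1.50 log units; beyond the scatter), concerns a different group on the shared core and does not bear directly on this change; no pair in the set compares chloro with methyl. With nothing to point either way, the step of a 1.3-fold higher number from compound 3 to compound 4 (0.11 log units; within the scatter) is expected to stay within the scatter. Compound 4 is therefore estimated at 3.2 nM, in a range from 1 nM to 10 nM.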

Compound 4, half-maximal inhibitory concentration: 3.16 nM
The estimate for compound 4 lay 1.0-fold (0.01 log units) above the measured number, within the range that was stated.
By their numbers in this assay, from the lowest: compounds 3 and 4 (each within the scatter of the next); then compound 2; then compound 1.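

In this assay, methyl in place of chloro on this aromatic carbon, ortho to a large group, gives a 1.3-fold higher number from compound 3 to compound 4 (0.10 log units; within the scatter), so the two groups cannot be told apart here. This is the only pair shown that compares them, and it shows that the chloro is not needed to keep the number this low when the 1,3,5-trimethyl-1H-pyrazol-4-yl group is present.

From the compounds shown here alone, whether a methoxy group or an amine at this position would read the same remains open, as does whether the match holds with other groups in place of the 1,3,5-trimethyl-1H-pyrazol-4-yl group. Nothing available gives a reason why chloro and methyl read alike here.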